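A few compounds are considered here, and "the series" means these few. Any claim that something is new, unique, unknown or untested is made for them only; others in the source may bear on it.

Within the data shown here, in an ADME assay on L132 cells (Homo sapiens) for cytotoxicity, read by MTT assay, with a stated time of 72 h (a higher number here means a weaker inhibitor, a lower number a stronger inhibitor), compound 3 `COc1ccc(C2=C(c3cc(OC)c(OC)c(OC)c3)C(=O)C(O[SiH2]C(C)(C)C)C2)cc1OC(C)C` gives 7 ug/mL and holds the only true number among the three compounds measured. Compound 1 `C=CCOc1cc(C2=C(c3cc(OC)c(OC)c(OC)c3)C(=O)C(O)C2)ccc1OC` gives > 100 ug/mL and this is a limit of the assay. Compound 2 `COc1ccc(C2=C(c3cc(OC)c(OC)c(OC)c3)C(=O)C(O)C2)cc1Cl` gives < 1 ug/mL and this too is a limit. Compound 4 `COc1ccc(C2=C(c3cc(OC)c(OC)c(OC)c3)C(=O)C(O)C2)cc1OC(C)C` has not yet been measured and differs from compound 3 by one change a hydrogen atom in place of a group of 5 heavy atoms (4 carbon, 1 silicon; no ring), on an oxygen on a saturated carbon on an oxygen on a saturated carbon. Among the measured compounds shown here, no measured step makes this change directly. For the measured compounds named here, the one step that bears on it is an at least 100-fold lower number from compound 1 to compound 2 (2.00 log units; beyond the scatter) with chloro in place of allyloxy on an aromatic carbon. That large step lies at another place, but both of its compounds already carry the hydrogen on that oxygen. Compound 4 has an isopropoxy group there rather than chloro, so it is expected to lean toward the allyloxy end of that step. The expected step is a 4.3-fold higher number from compound 3 to compound 4 (0.63 log units; beyond the scatter) toward a higher number in this assay and it is only loosely estimated. For compound 4 the estimated value is 30 ug/mL with an expected range from 3 ug/mL to 200 ug/mL in this assay.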

Compound 4, half-maximal inhibitory concentration: > 100 ug/mL
Compound 4 gave a limit, no number; the forecaster's own chance of this, stated with the estimate: 35%; at least 3.3-fold (0.52 log units) between middle value and limit.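

In this assay, the oxygen on a saturated carbon proves to be a position that counts on its own, for a hydrogen atom in place of the group of 5 heavy atoms gives an at least 14-fold higher number from compound 3 to compound 4 (1.15 log units; beyond the scatter). With the hydrogen on that oxygen, the aromatic carbon also counts again, as isopropoxy in place of chloro gives an at least 100-fold higher number from compound 2 to compound 4 (2.00 log units; beyond the scatter), which places compound 4 on the allyloxy side of the earlier step. The step between the isopropyl and allyl groups cannot be read, since compound 1 and compound 4 both stand at a limit: the limit of > 100 ug/mL in this assay, at which 2 of the 4 values shown sit.

From the compounds shown here alone, it remains open whether a smaller group on that oxygen, such as acetyl or methyl, would give a readable number as the larger group does. Going by these compounds, it is also open how the group of 5 heavy atoms would act with chloro on the aromatic carbon, or how an amine would act there.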